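The compounds below may be only part of what the source reports. "The series", "measured", "known", "first", "only" and "open" are said of these compounds alone.

In an ADME assay on HEK-293T cells (Homo sapiens) for inhibition, read by MTT assay, with a stated time of 48 h (a lower number here means a stronger inhibitor, a higher number a weaker inhibitor), compound 1 `COc1cc(OC)c(-c2nc3cc(/C=C4\SC(=O)NC4=O)ccc3[nH]2)cc1OC` gives 15300 nM, and compound 2 `COc1cc(-c2nc3cc(/C=C4\SC(=O)N(CC(=O)N5CCCCC5)C4=O)ccc3[nH]2)cc(OC)c1OC` gives 21500 nM. These are the only two values measured so far, and the gap between them lies within the usual scatter of this assay, so compound 2 cannot be set apart from compound 1 on the numbers shown; both sit at the weak end of inhibition. Compound 3 `COc1cc(OC)c(-c2nc3cc(/C=C4\SC(=O)N(CC(=O)N5CCCCC5)C4=O)ccc3[nH]2)cc1OC` has not yet been measured. It differs from compound 2 by 2,4,5-trimethoxyphenyl in place of 3,4,5-trimethoxyphenyl on an aromatic carbon, a change that keeps every atom and rearranges only the methoxy pattern on the phenyl ring. Going by the values given here, with no step between measured compounds to draw on, and with compound 1 and compound 2 showing no difference beyond the scatter, the step of a 1.3-fold lower number from compound 2 to compound 3 (0.10 log units; within the scatter) is expected to stay within the scatter, with no direction favoured. Compound 3 is therefore estimated at 17000 nM, with a range from 8000 nM to 40000 nM.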

Compound 3, half-maximal inhibitory concentration: > 50000 nM
Compound 3 gave a limit, no number; the forecaster's own chance of this, stated with the estimate: 10%; at least 2.9-fold (0.46 log units) between middle value and limit.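

In this assay, the methoxy pattern of the phenyl ring on this aromatic carbon, between two ring nitrogen atoms, proves to matter: rearranging the same atoms gives an at least 2.3-fold higher number from compound 2 to compound 3 (0.36 log units; beyond the scatter). With 2,4,5-trimethoxyphenyl kept, ((piperidin-1-yl)carbonyl)methyl in place of hydrogen on the amide-type nitrogen in a ring gives an at least 3.2-fold higher number from compound 1 to compound 3 (0.51 log units; beyond the scatter), something compound 1 and compound 2 could not show, as they differ in both places and lie within the scatter of each other. Both steps rest on a limit for compound 3, not on a number: the limit of > 50000 nM in this assay, at which 1 of the 3 values shown sits.

As far as these compounds go, the true size of both steps stays open, as does whether the methoxy rearrangement would read the same with hydrogen on that nitrogen. From the compounds shown here alone, it is also open how a carboxylic acid or a morpholine amide would fare on that nitrogen in place of ((piperidin-1-yl)carbonyl)methyl.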